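An Amino Group Added to the Phenyl Ring

A few compounds are considered here, and "the series" means these few. Any claim that something is new, unique, unknown or untested is made for them only; others in the source may bear on it.

Of the compounds shown here, three sharing one core have been tested in a functional assay on MCF7 cells (Homo sapiens) for cytotoxicity, read by MTT assay, with a stated time of 96 h; on this read-out higher numbers stand for weaker inhibition and lower numbers for stronger inhibition. Compound 1 `COc1cccc(-n2cc(C(=O)c3cc(OC)c(OC)c(OC)c3)c(-c3ccccc3)c2)c1` gives 500 nM and compound 3 `COc1ccc(-n2cc(C(=O)c3cc(OC)c(OC)c(OC)c3)c(-c3ccccc3)c2)cc1` gives 120 nM. Compound 2 `COc1cc(C(=O)c2cn(-c3ccc(N)cc3)cc2-c2ccccc2)cc(OC)c1OC` gives 35 nM, the lowest number of the three, since a 14-fold lower number from compound 1 to compound 2 (1.15 log units; beyond the scatter) and a 3.4-fold higher number from compound 2 to compound 3 (0.54 log units; beyond the scatter) both lie beyond the scatter.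

Compound 4 `COc1cc(C(=O)c2cn(-c3ccc(N)cc3)cc2-c2cccc(N)c2)cc(OC)c1OC` differs from compound 2 by amino in place of hydrogen on an aromatic carbon, which cut one bond further out reads phenyl to 3-aminophenyl. Within the data shown here, no measured step touches this ring; the steps seen concern the ring on the aromatic nitrogen, where a 14-fold lower number from compound 1 to compound 2 (1.15 log units; beyond the scatter) was large and a 3.4-fold higher number from compound 2 to compound 3 (0.54 log units; beyond the scatter) modest. An amino group clearly mattered there, but at a different place, so for compound 4 only a small step, a 1.1-fold higher number from compound 2 to compound 4 (0.06 log units; within the scatter), is expected. Compound 4 is therefore estimated at 40 nM, within a range of 12 nM to 130 nM.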

Compound 4, half-maximal inhibitory concentration: 78 nM
Beside the measured number, compound 4's estimate is 2.0-fold (0.29 log units) below it, and the stated range covers the measured number.
By their numbers in this assay, from the lowest: compound 2; then compounds 4 and 3 (each within the scatter of the next); then compound 1.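

The phenyl ring is not a silent place: the change to 3-aminophenyl brings a 2.2-fold higher number from compound 2 to compound 4 (0.35 log units; beyond the scatter) and so moves toward weaker inhibition. An amino group therefore does not lower the number wherever it stands, for its advantage over methoxy on the ring on the aromatic nitrogen, seen in a 3.4-fold higher number from compound 2 to compound 3 (0.54 log units; beyond the scatter) as a rise on losing it, does not repeat on this ring. Nothing measured here offers a reason for this step. Going by these compounds, whether a hydroxyl group or a fluorine atom at this place would act like amino stays open.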